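Selenocyanate series: amide to ester at the carbonyl

This account rests on a few compounds, and the source may have more. Where it says the series, first, only, none or still open, it means among the compounds named here.

Measured compounds:
compound 1 `Cc1nc(N(C)c2ccc([Se]C#N)c(Cl)c2)c2ccccc2n1`, 12 nM
compound 2 `COc1ccc(N(C)c2nc(C)nc3ccccc23)cc1C(=O)NCC[Se]C#N`, 561 nM
compound 3 `C[Se]c1ccc(N(C)c2nc(C)nc3ccccc23)cc1C`, 9 nM

All three were run in a functional assay on LoVo cells (Homo sapiens) for inhibition, read by MTT assay, with a stated time of 48 h; on this read-out lower numbers stand for stronger inhibition and higher numbers for weaker inhibition. Compound 2 gives 561 nM, the highest number of the three; its gaps to compound 1 and to compound 3 both lie beyond the usual scatter, so compound 2 is the weakest of the set measured so far.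

Compound 4 `COc1ccc(N(C)c2nc(C)nc3ccccc23)cc1C(=O)OCC[Se]C#N` is not yet measured. It differs from compound 2 only at the carbonyl carbon, where (a group of 6 heavy atoms (3 carbon, 1 nitrogen, 1 oxygen, 1 selenium; no ring) in place of a group of 6 heavy atoms (3 carbon, 2 nitrogen, 1 selenium; no ring), on a carbonyl carbon). The selenocyanate chain is kept, and the carbonyl is kept; only the link to the chain changes. Among the compounds with values here, no measured pair shows this exact change, so the direction is not fixed by data. The step from compound 2 to compound 4 is expected to be small, a 1.1-fold lower number from compound 2 to compound 4 (0.05 log units; within the scatter), likely within the scatter. Compound 4 is therefore estimated at 500 nM, with a range from 180 nM to 1500 nM.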

Compound 4, half-maximal inhibitory concentration: 2960 nM
Compound 4: the middle estimate sits 5.9-fold (0.77 log units) below what was measured, and the stated range ends below it.
By their numbers in this assay, from the lowest: compounds 3 and 1 (each within the scatter of the next); then compound 2; then compound 4.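

In this assay, the link between the carbonyl carbon and the selenocyanate chain is not a neutral spot: replacing the amide with the ester gives a 5.3-fold higher number from compound 2 to compound 4 (0.72 log units; beyond the scatter). Within the data shown here, this is the first matched pair, and it shows that the link alone moves the number beyond the scatter, with the chain and carbonyl both kept. Nothing at hand accounts for this step.

From the compounds shown here alone, whether the loss of the amide hydrogen matters, or the ester oxygen itself, remains open. Going by these compounds, a methylated amide or a ketone at this carbonyl carbon could separate the two, and a longer chain remains untested here.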